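This account rests on a few compounds, and the source may have more. Where it says the series, first, only, none or still open, it means among the compounds named here.

Measured so far:
compound 1 `c1cc(OCc2ccc3ccccc3n2)cc(OCc2ccccc2-c2nn[nH]n2)c1` gives 20 nM in an assay on isolated protein for binding affinity to cysteinyl leukotriene receptor 1 (Cavia porcellus); on this read-out lower numbers stand for stronger inhibition and higher numbers for weaker inhibition.
compound 2 `COc1cc(COc2cccc(OCc3ccc4ccccc4n3)c2)cc(-c2nn[nH]n2)c1` gives 7 nM in this assay.

Compound 1 holds the higher of the two numbers; compound 2 lies beyond the scatter below it. Compound 3 `c1cc(OCc2ccc3ccccc3n2)cc(OCc2ccccc2Cc2nnn[nH]2)c1` is not yet measured. It differs from compound 1 by (1H-tetrazol-5-yl)methyl in place of 2H-tetrazol-5-yl on an aromatic carbon. Going by the values given here, no measured pair shows this change, so the data give no size for it. A modest step toward a weaker, higher number is expected: a 3.0-fold higher number from compound 1 to compound 3 (0.48 log units; beyond the scatter). Compound 3 is accordingly estimated at 60 nM, with a range from 15 nM to 250 nM.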

Compound 3, inhibition constant: 12 nM
Beside the measured number, compound 3's estimate is 5.0-fold (0.70 log units) above it, outside the stated range (below it).
By their numbers in this assay, from the lowest: compounds 2, 3 and 1 (each within the scatter of the next, the first and the last beyond it).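

In this assay, this position, ortho to a large group, accepts (1H-tetrazol-5-yl)methyl in place of 2H-tetrazol-5-yl with a step inside the scatter (a 1.7-fold lower number from compound 1 to compound 3 (0.22 log units; within the scatter)). The tetrazole ring therefore need not sit directly on the aromatic carbon for the number to hold at this level. Nothing available explains why the two groups read alike.

Going by these compounds, whether a longer chain such as (1H-tetrazol-5-yl)ethyl, or a carboxylic acid in place of the tetrazole, would hold here remains open. So does whether the same exchange reads alike on the core of compound 2.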